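A Different Aryl Group on the Core of Compound 1

The compounds below may be only part of what the source reports. "The series", "measured", "known", "first", "only" and "open" are said of these compounds alone.

Compound 1 `CC1=C(C(=O)Nc2ccc(Br)cc2)C(c2ccc(Cl)cc2Cl)N=C(SCc2ccccc2)N1` was tested in a functional assay on the whole organism (artery, strain albino) with Rattus norvegicus as the target, with a stated time of 300 min, at a dose of 10 mg/kg by the oral route; on this read-out higher numbers stand for more inhibition at the one dose given (going by the name of the read-out) and lower numbers for less inhibition. In this assay compound 1 gives 22.1%, the lowest of the three numbers recorded. Compound 2 `CC1=C(C(=O)Nc2ccc(Br)cc2)C(c2ccc(Cl)cc2Cl)N=C(SCc2ccc(Cl)cc2)N1` gives 38.5%, and compound 3 `CC1=C(C(=O)Nc2ccc(Br)cc2)C(c2ccc(Cl)cc2Cl)N=C(SCc2ccc(F)cc2)N1` gives 38.5%. The measured steps are a number 16.4 percentage points higher from compound 1 to compound 2 (beyond the scatter), a number 16.4 percentage points higher from compound 1 to compound 3 (beyond the scatter) and no change at the digits printed from compound 2 to compound 3 (within the scatter); each of them concerns the ring of the benzylsulfanyl group.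

Compound 4 `COc1ccc(C2N=C(SCc3ccccc3)NC(C)=C2C(=O)Nc2ccc(Br)cc2)cc1` differs from compound 1 at another place: 4-methoxyphenyl in place of 2,4-dichlorophenyl on a saturated ring carbon. Within the data shown here, none of the measured steps touches this saturated ring carbon, so there is no direct guide to how the number will move. The modest gains seen in the steps to compound 2 and compound 3 came from changes elsewhere and give no basis for assuming the same here. Among the measured compounds shown here, with no bearing step, the expectation is a change that stays within the scatter: a number 2.9 percentage points higher from compound 1 to compound 4 (within the scatter). Compound 4 is therefore estimated at 25%, within a range from 5% to 45%, the width reflecting the absence of any step that informs this change.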

Compound 4, a percentage reported as inhibition, in the whole organism at one dose (the size of the read-out at that dose, not a potency): 16.4%
The estimate for compound 4 lay 8.6 percentage points above the measured number; low and high end bracket the measured number.
By their numbers in this assay, from the lowest: compounds 4 and 1 (each within the scatter of the next); then compounds 2 and 3 (each within the scatter of the next).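

Among these compounds, this is the first measured step at the saturated ring carbon of the core. Putting 4-methoxyphenyl in place of 2,4-dichlorophenyl gives a number 5.7 percentage points lower from compound 1 to compound 4 (within the scatter) in this assay, so this read-out does not separate the two compounds, even though the two chlorine atoms give way to a methoxy oxygen. No supporting data are available to interpret this result.

Because the aryl group changes in more than one way at once, a single step cannot show what the chlorine atoms and the methoxy group each contribute, and a plain phenyl, 4-chlorophenyl or 4-hydroxyphenyl group here would help to separate them. Also open, going by these compounds, is whether the chloro and fluoro groups on the benzylsulfanyl ring, seen in compound 2 and compound 3, would behave alike alongside 4-methoxyphenyl.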